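The source may hold more compounds than are shown below. What is called first, only, known or untested is meant among the compounds shown, and "the series" means these compounds.

Going by the values given here, the three compounds measured so far share one amide core. Compound 1 `Cc1ccc2nc(NC(=O)c3cn(-c4ccccc4)nc3-c3ccc(F)cc3)sc2c1`, compound 2 `O=C(Nc1nc2ccc(F)cc2s1)c1cn(-c2ccccc2)nc1-c1ccc(Cl)cc1` and compound 3 `O=C(Nc1nc2ccc(Cl)cc2s1)c1cn(-c2ccccc2)nc1-c1ccc(Cl)cc1` were tested in a functional assay on U-87MG ATCC cells for cytotoxicity against U-87 MG (Homo sapiens), read by MTT assay, with a stated time of 72 h; a lower number here means a stronger inhibitor, a higher number a weaker inhibitor. Compound 1 reaches only the limit of > 50000 nM in this assay, a limit rather than a number (the limit of > 50000 nM in this assay, at which 1 of the 3 values shown sits). Compound 2 gives 7770 nM in this assay. Compound 3 gives 5870 nM in this assay. Of the two numbers shown, compound 3 holds the lower, with compound 2 nearest; the step of a 1.3-fold lower number from compound 2 to compound 3 (0.12 log units; within the scatter) lies within the scatter, so the two cannot be ordered.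

Compound 4 `Cc1ccc2nc(NC(=O)c3cn(-c4ccccc4)nc3-c3ccc(Cl)cc3)sc2c1` has not yet been measured in this assay. It differs from compound 3 by methyl in place of chloro on an aromatic carbon. Among the compounds with values here, the only measured step on that ring, from compound 2 to compound 3, exchanged fluoro for chloro and stayed within the scatter; it says nothing about a methyl. Compound 1 also carries a methyl at that place, and in this assay its result is a limit. That points toward a weaker result for compound 4 than for compound 3. Compound 4 is therefore expected to give about 20000 nM in this assay, within a range of 6000 nM to 60000 nM. This estimate means an expected step of a 3.4-fold higher number from compound 3 to compound 4 (0.53 log units; beyond the scatter), a move toward weaker inhibition.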

Compound 4, half-maximal inhibitory concentration: 33200 nM
Compound 4: the middle estimate sits 1.7-fold (0.22 log units) below what was measured; measured number inside the range.
By their numbers in this assay, from the lowest: compounds 3 and 2 (each within the scatter of the next); then compound 4. At a limit, above all of these: compound 1.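

In this assay, going by these compounds alone, methyl at this place gives the first steps beyond the scatter between two measured numbers: a 5.7-fold higher number from compound 3 to compound 4 (0.75 log units; beyond the scatter) and a 4.3-fold higher number from compound 2 to compound 4 (0.63 log units; beyond the scatter), both moves toward weaker inhibition. The earlier compounds shown here showed only that fluoro and chloro at this place could not be ordered, whereas methyl now stands apart from both halogens. Chloro in place of fluoro on an aromatic carbon, with the methyl kept, gives an at least 1.5-fold lower number from compound 1 to compound 4 (0.17 log units; that floor lies within the scatter), a step that starts from a limit and does not settle whether this exchange matters on that core: the same change on two cores in this assay, a 1.3-fold lower number (0.12 log units; within the scatter) from compound 2 to compound 3 and an at least 1.5-fold lower number (0.17 log units; that floor lies within the scatter) from compound 1 to compound 4; the limit leaves it open whether they differ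

Only chloro, fluoro and methyl are shown at this place, so it remains open how an amine, a methoxy group, a carboxylic acid or a longer chain would compare with them. As far as these compounds go, the step from chloro to methyl also rests on a single pair, and how far it carries to other cores remains open.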